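A few compounds are considered here, and "the series" means these few. Any claim that something is new, unique, unknown or untested is made for them only; others in the source may bear on it.

Among the measured compounds shown here, in a functional assay on SK-N-AS cells (Homo sapiens) for antiproliferative activity, with a stated time of 72 h (a higher number here means a weaker inhibitor, a lower number a stronger inhibitor), compound 2 (`COc1ccc(C(=O)N(CCC(=O)NCc2ccccc2)Cc2ccc(C(=O)NO)cc2)cc1`) gives 1740 nM, the lower of the two numbers measured so far, while compound 1 (`COc1cc(OC)cc(C(=O)N(CCC(=O)NCc2ccccc2)Cc2ccc(C(=O)NO)cc2)c1`) gives 9470 nM. Compound 3 (`Cc1ccc(C(=O)N(CCC(=O)NCc2ccccc2)Cc2ccc(C(=O)NO)cc2)cc1`) differs from compound 2 by methyl in place of methoxy on an aromatic carbon, para to a large group: methyl in place of methoxy on an aromatic carbon. For the measured compounds named here, only one measured step bears on this change, and only indirectly: a 5.4-fold lower number from compound 1 to compound 2 (0.74 log units; beyond the scatter), which came with 4-methoxyphenyl in place of 3,5-dimethoxyphenyl on a carbonyl carbon. Going by the values given here, that step is a modest one, but it is a different exchange, and no measured compound carries the methyl group. No clear direction can be drawn from it, so no shift beyond the scatter is expected in this assay. The expected change is a 1.1-fold higher number from compound 2 to compound 3 (0.06 log units; within the scatter), which remains an estimate. For compound 3 the estimated value is 2000 nM, with an expected range of 900 nM to 4500 nM.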

Compound 3, half-maximal inhibitory concentration: 910 nM
Compound 3: the middle estimate sits 2.2-fold (0.34 log units) above what was measured, within the range that was stated.
By their numbers in this assay, from the lowest: compounds 3 and 2 (each within the scatter of the next); then compound 1.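

In this assay, putting methyl in place of methoxy on this aromatic carbon, para to a large group, gives a 1.9-fold lower number from compound 2 to compound 3 (0.28 log units; within the scatter), so in this one pair the methoxy group can be exchanged for methyl without a shift beyond the scatter. The step of a 10-fold lower number from compound 1 to compound 3 (1.02 log units; beyond the scatter) is large and beyond the scatter, so the 4-methylphenyl group, like the 4-methoxyphenyl group before it, stands well apart from the 3,5-dimethoxyphenyl group. Nothing available here explains why methyl and methoxy read alike at this position.

From the compounds shown here alone, it remains open whether an amine, a carboxylic acid or a chlorine atom on this carbon would leave the number in the same place, and whether a longer chain such as propyl would do so. Going by these compounds, it is also open whether methyl would read the same on another carbon of this ring.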